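This account rests on a few compounds, and the source may have more. Where it says the series, first, only, none or still open, it means among the compounds named here.

Compound 1 `CC[C@H](C)[C@H](NC(=O)CN(c1nc(Cl)nc2[nH]cnc12)C1CC1)C(=O)O` has the lowest of the three numbers measured in a functional assay on the whole organism (Tail, strain ICR) with Mus musculus as the target, in the tail flick test, with a stated time of 90 min, at a dose of 25 umol/kg by the oral route (a lower number here means a weaker effect, a higher number a stronger effect of the compound at the dose given), where compound 1 gives 27.4%; the nearest is compound 2 `N=C(N)NCCC[C@H](NC(=O)CN(c1nc(Cl)nc2[nH]cnc12)C1CC1)C(=O)OCc1ccccc1` with 30.4% and the furthest compound 3 `CC[C@H](C)[C@H](NC(=O)CN(c1nc(Cl)nc2[nH]cnc12)C1CC1)C(=O)OCc1ccccc1` with 36.3%, both within the scatter of compound 1. The two steps measured so far, a number 8.9 percentage points higher from compound 1 to compound 3 (within the scatter) and a number 5.9 percentage points higher from compound 2 to compound 3 (within the scatter), both stay within the scatter, and neither touches the place changed here. Compound 4 `CC(C)[C@H](NC(=O)CN(c1nc(Cl)nc2[nH]cnc12)C1CC1)C(=O)O` differs from compound 1 by hydrogen in place of methyl on a saturated chain carbon, three bonds along the chain from an amide-type nitrogen and a carbonyl carbon. For the measured compounds named here, no measured step bears on this change, so nothing beyond the scatter is expected in either direction. Compound 4 is therefore estimated at 27.4% in this assay, within 12% to 42%, which is expected to mean no change at the digits printed from compound 1 to compound 4 (within the scatter).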

Compound 4, a percentage reported as activity, at one dose (the size of the read-out at that dose, not a potency): 30.3%
Compound 4: the middle estimate sits 2.9 percentage points below what was measured; low and high end bracket the measured number.
By their numbers in this assay, from the lowest: compounds 1, 4, 2 and 3 (each within the scatter of the next).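

In this assay, for the compounds shown here, the change from sec-butyl to isopropyl gives a number 2.9 percentage points higher from compound 1 to compound 4 (within the scatter), the first measured step at this position. Losing this methyl from the side chain therefore leaves the read-out within the scatter at the single dose and time given. No available evidence bears on this result. As far as these compounds go, whether a longer chain, a phenyl ring or an amine at this place would move the number beyond the scatter stays open. Also open, from the compounds shown here alone, is whether isopropyl gives a similar number when the carboxylic acid is replaced by its benzyl ester.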